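A few compounds are considered here, and "the series" means these few. Any claim that something is new, unique, unknown or untested is made for them only; others in the source may bear on it.

Working notes on the series. Compound 1 `Fc1cccc(F)c1C#Cc1ccc2cn[nH]c2c1` gives 97% in a functional assay on LS174T cells (Homo sapiens) for inhibition, with a stated time of 4 days, tested at 10 uM (on this read-out lower numbers stand for a weaker effect and higher numbers for a stronger effect at the one concentration tested), and compound 2 `Cn1ncc2ccc(C#Cc3c(F)cccc3F)cc21` gives 98.1%; the step of a number 1.1 percentage points higher from compound 1 to compound 2 (within the scatter) lies within the scatter. Compound 3 `Fc1cccc(F)c1C#Cc1ccnc2ccccc12` gives 59% in this assay and stands lowest of the three numbers, beyond the scatter from compound 1 and from compound 2. Compound 4 `Fc1cccc(F)c1C#Cc1ccnc2cc(Cl)ccc12` differs from compound 3 by chloro in place of hydrogen on an aromatic carbon. Within the data shown here, the one measured step concerns methyl in place of hydrogen on an aromatic nitrogen and does not bear on a chloro entering at an aromatic carbon; no measured pair shows chloro in place of hydrogen. The expected step is therefore a number 1 percentage points higher from compound 3 to compound 4 (within the scatter), not beyond the scatter. The estimate for compound 4 in this assay is 60%, within 35% to 85%.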

Compound 4, a percentage reported as inhibition, at one concentration (the size of the read-out at that concentration, not a potency): 74.3%
Estimate against measurement, compound 4: 14.3 percentage points below; measured number inside the range.
By their numbers in this assay, from the lowest: compound 3; then compound 4; then compounds 1 and 2 (each within the scatter of the next).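

In this assay, chloro in place of hydrogen on this aromatic carbon gives a number 15.3 percentage points higher from compound 3 to compound 4 (beyond the scatter), so the read-out responds to a substituent at this position of the shared core. Among these compounds, no earlier pair covered this position, and the one earlier step, on an aromatic nitrogen, stayed within the scatter. Nothing at hand explains the rise.

From the compounds shown here alone, whether a methoxy group, an amine or a carboxylic acid on the same carbon would move the number in the same direction stays open. So does the effect of chloro on the other carbons of this ring.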